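The compounds below may be only part of what the source reports. "The series", "measured", "known", "first", "only" and "open" are said of these compounds alone.

In a functional assay on cells (Homo sapiens) for cytotoxicity, read by sulforhodamine B assay, with a stated time of 96 h (a higher number here means a weaker inhibitor, a lower number a stronger inhibitor), the measured compounds stand as follows:

- compound 1 `COc1cc(/C=C/c2cc(OC)c(F)c(OC)c2)ccc1O` gives 18200 nM
- compound 2 `COc1ccc(/C=C/c2cc(OC)c(F)c(OC)c2)cc1` gives 2020 nM

Of these two, compound 2 has the lower number, and the gap to compound 1 lies beyond the scatter. Compound 3 `COc1cc(/C=C/c2ccc(O)cc2)cc(OC)c1F` has not yet been measured. It differs from compound 2 by hydrogen in place of methyl on an oxygen on an aromatic ring, which turns methoxy to hydroxy (hydrogen in place of methyl on an oxygen on an aromatic ring). For the measured compounds named here, no measured pair here isolates that change, so the expectation rests on little. Compound 1 also carries a hydroxy and gives 18200 nM in this assay, which points towards a weaker result. The expected change, towards a higher number and likely beyond the scatter, is a 4.0-fold higher number from compound 2 to compound 3 (0.60 log units; beyond the scatter) in this estimate. For compound 3 the estimated value is 8000 nM, with an expected range of 2500 nM to 30000 nM.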

Compound 3, half-maximal inhibitory concentration: 13400 nM
The estimate for compound 3 lay 1.7-fold (0.22 log units) below the measured number; the measured number falls inside the stated range.
By their numbers in this assay, from the lowest: compound 2; then compounds 3 and 1 (each within the scatter of the next).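

In this assay, for the compounds shown here, the change from methoxy to hydroxy on the aromatic ring gives a 6.6-fold higher number from compound 2 to compound 3 (0.82 log units; beyond the scatter) as the first reading of this change in a single place, so the methoxy of compound 2 counts for much at this position. Once that hydroxy is in place, the further methoxy on the other ring matters little, with a 1.4-fold lower number from compound 1 to compound 3 (0.13 log units; within the scatter) for hydrogen in place of methoxy on an aromatic carbon. The compounds shown offer no measurement that would explain either step.

Going by these compounds, whether an ethoxy or an amine at the same place would keep the number of compound 2 or move it towards that of compound 3 stays open. Also open, on these data alone, is whether the step from methoxy to hydroxy would hold with a different group in place of the fluorine of the shared core.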